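Cyano for Methoxy on the Phenyl Ring of Compound 2

This account rests on a few compounds, and the source may have more. Where it says the series, first, only, none or still open, it means among the compounds named here.

Of the compounds shown here, three that share one core have been tested in a functional assay on HT-29 cells (Homo sapiens) for cytotoxicity, read by MTT assay, with a stated time of 48 h; on this read-out higher numbers stand for weaker inhibition and lower numbers for stronger inhibition. Compound 2 `COC(=O)/C=C/c1ccc2c(c1)C(=O)C(=O)N2Cc1ccc(OC)cc1` gives 30 nM and stands lowest of the three numbers. Compound 1 `COc1ccc(CN2C(=O)C(=O)c3cc(/C=C/C(=O)OC(C)(C)C)ccc32)cc1` gives 480 nM, and compound 3 `COc1ccc(CN2C(=O)C(=O)c3cc(/C=C/C(=O)N4CCCC4)ccc32)cc1` gives 5230 nM. All measured steps concern the group on the carbonyl carbon of the side chain: a 16-fold lower number from compound 1 to compound 2 (1.20 log units; beyond the scatter), an 11-fold higher number from compound 1 to compound 3 (1.04 log units; beyond the scatter), and a 170-fold higher number from compound 2 to compound 3 (2.24 log units; beyond the scatter). Each of these steps lies beyond the scatter, so compound 2 is the most potent of the three in this assay.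

Compound 4 `COC(=O)/C=C/c1ccc2c(c1)C(=O)C(=O)N2Cc1ccc(C#N)cc1` has not yet been measured. It differs from compound 2 in one place: cyano in place of methoxy on an aromatic carbon. Going by the values given here, none of the measured steps touches this position; every measured compound carries the 4-methoxyphenyl, and the steps all change the group on the carbonyl carbon instead. Among the compounds with values here, the data thus give no direction for this change, and no measured step bears on it. Compound 4 is therefore estimated to land near the number of compound 2, at 40 nM, with a range from 8 nM to 250 nM. Within the data shown here, this estimate means a step of a 1.3-fold higher number from compound 2 to compound 4 (0.12 log units; within the scatter), expected to stay within the scatter, though with wide uncertainty given that no measured pair informs it.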

Compound 4, half-maximal inhibitory concentration: 50 nM
Estimate against measurement, compound 4: 1.3-fold (0.10 log units) below; the measured number falls inside the stated range.
By their numbers in this assay, from the lowest: compounds 2 and 4 (each within the scatter of the next); then compound 1; then compound 3.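

Going by these compounds alone, the swap of 4-methoxyphenyl to 4-cyanophenyl is the first change at this position on the phenyl ring, and it gives a 1.7-fold higher number from compound 2 to compound 4 (0.22 log units; within the scatter) in this assay, a step within the scatter, so this read-out does not separate the two groups. The earlier compounds shown here all carried the 4-methoxyphenyl and differed only in the group on the carbonyl carbon, where changes such as a 170-fold higher number from compound 2 to compound 3 (2.24 log units; beyond the scatter) moved the number far beyond the scatter, whereas this change on the aromatic carbon leaves compound 4 level with compound 2, the lowest of the earlier three. No evidence is available on why the two groups give such similar numbers.

On these data alone, whether this position accepts other groups in the same way stays open, for example an amine, a carboxylic acid or a longer alkoxy chain in place of the methoxy. Also open, as far as these compounds go, is whether cyano in place of methoxy would give a similarly small step when the carbonyl carbon carries tert-butoxy, as in compound 1, or pyrrolidin-1-yl, as in compound 3.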